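Lactam to pyridine amide: the clearance to come

A few compounds are considered here, and "the series" means these few. Any claim that something is new, unique, unknown or untested is made for them only; others in the source may bear on it.

Compound 1 `CN(c1ccn(C)n1)c1cnc(NCc2c(F)ccc3c2CCO3)c2cn[nH]c(=O)c12` carries methyl(1-methyl-1H-pyrazol-3-yl)amino on an aromatic carbon, and in an ADME assay on microsomes from liver (Homo sapiens) for metabolic stability, read by LC-MS, using NADPH, with stated times of 5 min and 30 min, tested at 1 uM (on this read-out lower numbers stand for slow clearance and higher numbers for fast clearance), compound 1 gives 62 mL.min-1.g-1. Compound 3 `Cn1nccc1-c1cnc(NCc2c(F)ccc3c2CCO3)c2cn[nH]c(=O)c12` differs from it only in that 1-methyl-1H-pyrazol-5-yl stands in place of that group; in this assay compound 3 gives 14 mL.min-1.g-1, a step of a 4.4-fold lower number from compound 1 to compound 3 (0.65 log units; beyond the scatter). Compound 2 `O=C1CCCN1c1cnc(NCc2c(F)ccc3c2CCO3)n2cnnc12` is built on a different core. In this assay compound 2 gives < 3 mL.min-1.g-1, which is a limit of the assay and not a number, as the limit of < 3 mL.min-1.g-1 in this assay, at which 1 of the 3 values shown sits, records. Compound 2 thus stands at the low edge of everything measured so far. Compound 4 `O=C(Nc1cnc(NCc2c(F)ccc3c2CCO3)n2cnnc12)c1cccnc1` is obtained from compound 2 by ((pyridin-3-yl)carbonyl)amino in place of 2-oxopyrrolidin-1-yl on an aromatic carbon. Among the compounds with values here, no measured step bears on this change: the only step recorded, from compound 1 to compound 3, concerns another group on another core and offers no guide. Since compound 2 sits at the limit, compound 4 can only come out at the limit again or higher, and a modest rise is the expectation. Compound 4 is expected to give 8 mL.min-1.g-1 in this assay, within a range from 3 mL.min-1.g-1 to 25 mL.min-1.g-1, an expected step of an at least 2.6-fold higher number from compound 2 to compound 4 (0.42 log units; beyond the scatter).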

Compound 4, intrinsic clearance in microsomes: < 3 mL.min-1.g-1
Compound 4 ended at the assay's limit; the forecaster's own chance of this, stated with the estimate: 35%; middle value at least 2.6-fold (0.42 log units) from the limit.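

In this assay the step from compound 2 to compound 4 cannot be read, because both compounds sit at the same limit of the assay: the limit of < 3 mL.min-1.g-1 in this assay, at which 2 of the 4 values shown sit. The compounds shown leave open how the clearance of compound 2 and compound 4 truly compares beneath that limit.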